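One Methoxy Group, Two Cores, One Expected Step

The compounds below may be only part of what the source reports. "The series", "measured", "known", "first", "only" and "open" are said of these compounds alone.

Compound 1 `O=C(/C=C/c1ccccc1)c1ccc2[nH]c(=O)oc2c1` is the simplest of the three measured compounds. In a functional assay on BV-173 cells (Homo sapiens) for cytotoxicity, read by MTT assay, with a stated time of 72 h (on this read-out higher numbers stand for weaker inhibition and lower numbers for stronger inhibition), compound 1 gives 18400 nM. Compound 2 `COc1ccc(/C=C/C(=O)c2ccc3[nH]c(=O)oc3c2)cc1` carries one extra group, (methoxy in place of hydrogen on an aromatic carbon), and in this assay compound 2 gives 9200 nM. That single change made a 2.0-fold lower number from compound 1 to compound 2 (0.30 log units; within the scatter), a step that stays inside the ordinary run-to-run variation, so the two numbers cannot be told apart with confidence.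

Compound 3 `COc1ccccc1N1CCN(Cn2c(=O)oc3cc(C(=O)/C=C/c4ccccc4)ccc32)CC1` is built on a different core; the difference between the two cores is not broken down here. In this assay compound 3 gives 9200 nM, level with compound 2 at the digits shown.

Compound 4 `COc1ccc(/C=C/C(=O)c2ccc3c(c2)oc(=O)n3CN2CCN(c3ccccc3OC)CC2)cc1` is not yet measured. It differs from compound 3 by methoxy in place of hydrogen on an aromatic carbon, the same change, at the same place, that separates compound 1 from compound 2. Because the earlier step was a 2.0-fold lower number from compound 1 to compound 2 (0.30 log units; within the scatter), a step of similar size is expected here, a 1.5-fold lower number from compound 3 to compound 4 (0.19 log units; within the scatter), resting on that single precedent. The estimate for compound 4 in this assay is 6000 nM, expected to fall between 2500 nM and 15000 nM.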

Compound 4, half-maximal inhibitory concentration: 5400 nM
For compound 4 the middle estimate is 1.1-fold (0.05 log units) above the measured one; low and high end bracket the measured number.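

In this assay, putting methoxy in place of hydrogen on the core of compound 3 gives a 1.7-fold lower number from compound 3 to compound 4 (0.23 log units; within the scatter). Set beside the same change on the core of compound 1, the two steps agree: the same change on two cores in this assay, a 2.0-fold lower number (0.30 log units; within the scatter) from compound 1 to compound 2 and a 1.7-fold lower number (0.23 log units; within the scatter) from compound 3 to compound 4, 1.2-fold (0.07 log units) apart, within the scatter of two such steps. The change therefore reads alike on both cores, yet each step on its own lies within the scatter, so these numbers do not show that methoxy really shifts the read-out, and two pairs say nothing about how it would behave on a third core.

Among the compounds shown, only hydrogen and methoxy appear at this place on the aromatic ring, which leaves open what a hydroxyl group, an amine, a carboxylic acid or a longer chain such as ethoxy would give there. Also open, as far as these compounds go, is whether methoxy elsewhere on that ring would give a step of similar size on both cores.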